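Aryl Swaps on a Shared Core: Expecting a Flat Step

A few compounds are considered here, and "the series" means these few. Any claim that something is new, unique, unknown or untested is made for them only; others in the source may bear on it.

Three compounds share one core and differ only in the aryl group attached to the five-membered aromatic ring with 4 nitrogen. Compound 1 `Cc1cc(NC(=O)Cn2nnc(-c3ccc(Cl)c(Cl)c3)n2)n(C2CCCCC2)n1` carries a 3,4-dichlorophenyl there, and in an assay on HEK293 cells for activation of Kir3.1/Kir3.2 (Homo sapiens), read by thallium flux (on this read-out lower numbers stand for smaller maximal responses and higher numbers for larger maximal responses), compound 1 reaches 84%. Compound 2 `Cc1cc(NC(=O)Cn2nnc(-c3cc(Cl)cc(Cl)c3)n2)n(C2CCCCC2)n1` carries a 3,5-dichlorophenyl, and in this assay compound 2 reaches 82%; a number 2 percentage points lower from compound 1 to compound 2 (within the scatter). Compound 3 `COc1cccc(-c2nnn(CC(=O)Nc3cc(C)nn3C3CCCCC3)n2)c1` carries a 3-methoxyphenyl, and in this assay compound 3 reaches 76%. Compound 3 stands within the scatter of both others: a number 8 percentage points lower from compound 1 to compound 3 (within the scatter), and a number 6 percentage points lower from compound 2 to compound 3 (within the scatter).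

Compound 4 `Cc1cc(NC(=O)Cn2nnc(-c3ccc(C(F)(F)F)cc3)n2)n(C2CCCCC2)n1` has not been measured. It differs from compound 3 in one place: 4-(trifluoromethyl)phenyl in place of 3-methoxyphenyl on an aromatic carbon. Both measured steps that change this aryl group bear on the new one, a number 8 percentage points lower from compound 1 to compound 3 (within the scatter) and a number 6 percentage points lower from compound 2 to compound 3 (within the scatter), and neither lies beyond the scatter. The three values in this assay thus show the aryl group moving the maximal response little among compound 1, compound 2 and compound 3, and a similar outcome is expected here, with a number 4 percentage points higher from compound 3 to compound 4 (within the scatter) expected to stay within the scatter. For compound 4 in this assay the estimate is 80%, with a range from 68% to 92%.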

Compound 4, largest response reached (Emax), in percent of the reference or control that the assay uses: 94%
Estimate against measurement, compound 4: 14 percentage points below, and the stated range ends below it.
By their numbers in this assay, from the lowest: compounds 3, 2, 1 and 4 (each within the scatter of the next, the first and the last beyond it).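

At this aromatic carbon of the five-membered ring, 4-(trifluoromethyl)phenyl gives the only aryl steps shown that lie beyond the scatter in this assay: a number 18 percentage points higher from compound 3 to compound 4 (beyond the scatter) and a number 12 percentage points higher from compound 2 to compound 4 (beyond the scatter). The aryl group at this position can therefore move the maximal response measurably, which the three earlier compounds did not show, but the reach of the change is limited, with a number 10 percentage points higher from compound 1 to compound 4 (within the scatter), so 4-(trifluoromethyl)phenyl and 3,4-dichlorophenyl cannot be told apart here. No measurement at hand explains why the new group separates from 3-methoxyphenyl and 3,5-dichlorophenyl but not from 3,4-dichlorophenyl.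

As far as these compounds go, all four compounds keep a phenyl ring at this position with only chlorine, methoxy or trifluoromethyl on it, so how an amine or a carboxylic acid on that ring would read remains open. From the compounds shown here alone, it also remains open whether the higher response follows the trifluoromethyl group itself or its place on the phenyl ring, a question that 3-(trifluoromethyl)phenyl on the same core would address.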